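The source may report more compounds than this note shows. Statements on the series, on what has been measured and on what is new or still open speak of the compounds shown alone.

Measured in an ADME assay on CEM-SS cells (Homo sapiens) for cytotoxicity, read by XTT assay, with a stated time of 6 days; on this read-out higher numbers stand for lower toxicity in this test and lower numbers for higher toxicity in this test:
Compound 1 `CCCC(=O)OCSc1ccccc1C(=O)NCCCNC(C)=O`: 21.1 uM
Compound 2 `CCCC(=O)OCSc1ccccc1C(=O)N[C@H]1CCC[C@@H]1C(N)=O`: 31.2 uM; 43.3 uM (2 entries)
Compound 3 `CCCC(=O)OCSc1ccccc1C(=O)NCC(=O)NCCN(C)C`: 76.9 uM

Among the compounds with a single number in this assay, compound 3 stands highest. The nearest such value lies clearly under it, as a 3.6-fold higher number from compound 1 to compound 3 (0.56 log units; beyond the scatter) shows. The remaining compound has no single number, only (the several entries of compound 2 in this assay, 31.2 uM; 43.3 uM (2 entries)).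

The next compound, compound 4 `CCCC(=O)OCSc1ccccc1C(=O)NCC(=O)NCC(N)=O`, changes the side chain of compound 3 at one place: carbamoyl in place of (dimethylamino)methyl on a saturated chain carbon bound to an amide-type nitrogen. The dimethylamino end is lost, and the chain now finishes in a carbamoyl group.

Among the compounds with values here, only one measured step bears on this change, a 3.6-fold higher number from compound 1 to compound 3 (0.56 log units; beyond the scatter), and it brought in the (2-(dimethylamino)ethyl)carbamoyl group that compound 4 no longer has. A partial return toward lower numbers therefore seems likely, though the two side chains are not the same. Compound 2, which also carries a carbamoyl group, gives 31.2 uM; 43.3 uM (2 entries), and this argues against a fall all the way to the value of compound 1. The expected move is thus smaller than the measured step, toward a lower number: a 1.7-fold lower number from compound 3 to compound 4 (0.23 log units; within the scatter).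

For compound 4 the estimated value is 45 uM, with an expected range from 20 uM to 100 uM.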

Compound 4, half-maximal toxic concentration: > 100 uM
Compound 4 was reported as a limit; the forecaster's own chance of this, stated with the estimate: 15%; middle value at least 2.2-fold (0.34 log units) away from the limit.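

In this assay, compound 4 is the one compound shown that is reported as a limit and not as a number: the limit of > 100 uM in this assay, at which 1 of the 4 values shown sits. The step of an at least 1.3-fold higher number from compound 3 to compound 4 (0.11 log units; that floor lies within the scatter) gives only a floor, and it shows that carbamoyl in place of (dimethylamino)methyl on a saturated chain carbon bound to an amide-type nitrogen does not bring the partial return toward lower numbers, so the dimethylamino end is not required for the high reading of compound 3. The wider comparison, an at least 4.7-fold higher number from compound 1 to compound 4 (0.67 log units; beyond the scatter), lies beyond the scatter, and together with a 3.6-fold higher number from compound 1 to compound 3 (0.56 log units; beyond the scatter) it shows that both side chains carrying a second amide-type carbonyl in place of 2-acetamidoethyl read higher than compound 1, whichever of the two end groups they carry.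

As far as these compounds go, how far compound 4 lies past its limit cannot be read, so the true size of both of its steps stays open. Also open, from the compounds shown here alone, is whether a carboxylic acid at the end of this side chain, or a longer chain ending in carbamoyl, would stay at the limit in this assay or return to lower numbers.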